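The source may report more compounds than this note shows. Statements on the series, on what has been measured and on what is new or still open speak of the compounds shown alone.

Measured compounds:
compound 1 `Cn1c(=O)[nH]c2ccc(OCc3ccc(Cl)cc3)cc21`
compound 2 `Cn1c(=O)[nH]c2ccc(OCc3ccc(Cl)c(Cl)c3)cc21`
compound 3 `O=C1Nc2ccc(OCc3cccc(Cl)c3)cc2C1=O`

In an assay on cells for inhibition of Amine oxidase [flavin-containing] A (Homo sapiens), read by fluorescence, with stated times of 30 min and 15 min (a lower number here means a stronger inhibitor, a higher number a weaker inhibitor), compound 1 gives > 500000 nM, which is a limit of the assay and not a number. Compound 2 gives > 500000 nM, also a limit. Among the compounds with values here, compound 3 gives 311000 nM, the only number in the set; the other two values sit at the limit of > 500000 nM in this assay, at which 2 of the 3 values shown sit. The difference between the core of compound 3 and that of compound 1 is not broken down here. Compound 4 `O=C1Nc2ccc(OCc3ccc(Cl)c(Cl)c3)cc2C1=O` is still to be measured. The change from compound 3 to compound 4 is chloro in place of hydrogen on an aromatic carbon. The same kind of change, (chloro in place of hydrogen on an aromatic carbon), with the new chloro meta rather than para to the large group, made the step that the two limits leave unreadable from compound 1 to compound 2, unreadable because both ends are limits. With compound 3 near the limit, the step of a 1.0-fold higher number from compound 3 to compound 4 (0.01 log units; within the scatter) is expected to be small. Compound 4 is estimated at 320000 nM, between 100000 nM and 1000000 nM.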

Compound 4, half-maximal inhibitory concentration: 117000 nM
For compound 4 the middle estimate is 2.7-fold (0.44 log units) above the measured one, within the range that was stated.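

In this assay, chloro in place of hydrogen on an aromatic carbon gives a 2.7-fold lower number from compound 3 to compound 4 (0.42 log units; beyond the scatter) on the core of compound 3. The same change on the core of compound 1 cannot be read, since compound 1 and compound 2 are both limits of the assay and not numbers: the limit of > 500000 nM in this assay, at which 2 of the 4 values shown sit. The change is therefore shown to act on one core only, and nothing here shows whether it carries over to the other.

Open, on these data alone, is whether an amine or a carboxylic acid at the same place on the ring would shift the value as chloro does. Also open, as far as these compounds go, is how a longer chain between the core and that ring would affect the value.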